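Dropping the fluoro from a halogenated fused-ring amide

The compounds below may be only part of what the source reports. "The series", "measured", "known", "first", "only" and "open" are said of these compounds alone.

The four compounds share one core. Compound 1 `C#CCn1cc(C(=O)NC(CC(=O)Nc2ccccc2)c2ccccc2)c(=O)c2cccnc21` carries no halogen on it, while compound 2 `C#CCn1cc(C(=O)NC(CC(=O)Nc2ccccc2)c2ccccc2)c(=O)c2cc(F)c(Cl)nc21` carries fluoro and chloro. In a functional assay on DU-145 cells (Homo sapiens) for cytotoxicity, read by MTT assay, with a stated time of 72 h (a lower number here means a stronger inhibitor, a higher number a weaker inhibitor), compound 1 gives 7200 nM and compound 2 gives 5900 nM, the lower of the two numbers, although the two lie within the scatter of each other. Compound 3 `C#CCn1cc(C(=O)NC(CC(=O)NC2CCCC2)c2ccccc2)c(=O)c2cc(F)c(Cl)nc21` reaches only a limit of > 10000 nM in this assay. The step of an at least 1.6-fold higher number from compound 2 to compound 3 (0.22 log units; that floor lies within the scatter) concerns cyclopentyl in place of phenyl and does not bear on compound 4 `C#CCn1cc(C(=O)NC(CC(=O)Nc2ccccc2)c2ccccc2)c(=O)c2ccc(Cl)nc21`, which differs from compound 2 by hydrogen in place of fluoro on an aromatic carbon. Among the compounds with values here, no measured step covers this change alone; compound 1 and compound 2 differ by both halogens and their values lie within the scatter. The expected step is a 1.1-fold higher number from compound 2 to compound 4 (0.04 log units; within the scatter), none beyond the scatter. Compound 4 is estimated at 6500 nM, from 3000 nM to 14000 nM.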

Compound 4, half-maximal inhibitory concentration: > 10000 nM
Compound 4: only a limit was reported (the forecaster's own chance of this, stated with the estimate: 15%); middle value at least 1.5-fold (0.18 log units) away from the limit.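

In this assay compound 4 gives > 10000 nM, which is a limit of the assay and not a number. Hydrogen in place of fluoro, with the chloro kept, gives an at least 1.6-fold higher number from compound 2 to compound 4 (0.22 log units; that floor lies within the scatter), while chloro in place of hydrogen gives an at least 1.3-fold higher number from compound 1 to compound 4 (0.14 log units; that floor lies within the scatter), so for the first time a single change on this ring is read, though neither floor leaves the scatter and neither step can be sized. Compound 4 shares its limit with another compound shown: the limit of > 10000 nM in this assay, at which 2 of the 4 values shown sit.

Going by these compounds, how far the true value of compound 4 lies from that limit stays open. So does what an amine or a methoxy group on this aromatic carbon would give.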